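This account rests on a few compounds, and the source may have more. Where it says the series, first, only, none or still open, it means among the compounds named here.

Measured in an ADME assay on the whole organism for pharmacokinetics, with Homo sapiens as the target; a higher number here means that a larger share of the oral dose reaches the circulation, a lower number that a smaller share of the oral dose reaches the circulation:
Compound 1 `COc1ccccc1NS(=O)(=O)c1ccc2nc(-c3ccccc3)c(-c3ccccc3)nc2c1` gives 100%.
Compound 2 `O=C(O)c1ccccc1NS(=O)(=O)c1ccc2nc(-c3ccccc3)c(-c3ccccc3)nc2c1` gives 83.6%.
Compound 3 `O=S(=O)(Nc1ccc2ccccc2c1)c1ccc2nc(-c3ccccc3)c(-c3ccccc3)nc2c1` gives 100%.

Compound 1 stands level with compound 3 at the digits shown, and both sit above compound 2; the gap to compound 2 is a number 16.4 percentage points lower from compound 1 to compound 2 (beyond the scatter), while the comparison with compound 3 reads no change at the digits printed from compound 1 to compound 3 (within the scatter). Compound 4 `Cc1ccnc(NS(=O)(=O)c2ccc3nc(-c4ccccc4)c(-c4ccccc4)nc3c2)c1` is not yet measured. It differs from compound 1 in one place: 4-methylpyridin-2-yl in place of 2-methoxyphenyl on a sulfonamide nitrogen.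

Within the data shown here, two measured steps bear on this. The exchange of the group on the sulfonamide nitrogen for a different aromatic ring, as in compound 3, left the number unchanged, no change at the digits printed from compound 1 to compound 3 (within the scatter). Only the entry of a carboxy, as in compound 2, lowered it, a number 16.4 percentage points lower from compound 1 to compound 2 (beyond the scatter). The change to compound 4 brings no carboxy and no new hydrogen-bond donor, so any step in this assay is expected to stay within the scatter or be small and downward. Compound 4 is therefore expected to give 93%, between 75% and 100%, a step of a number 7 percentage points lower from compound 1 to compound 4 (within the scatter).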

Compound 4, oral bioavailability: 100%
Estimate against measurement, compound 4: 7 percentage points below; the measured number falls inside the stated range.
By their numbers in this assay, from the lowest: compound 2; then compounds 1, 3 and 4 (each within the scatter of the next).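

In this assay, a ring with a hetero atom, 4-methylpyridin-2-yl, on the sulfonamide nitrogen reads no change at the digits printed from compound 1 to compound 4 (within the scatter) and no change at the digits printed from compound 3 to compound 4 (within the scatter), so among compound 1, compound 3 and compound 4 a ring of carbon only is not required at this place. The new ring also stands clear of the carboxy compound, a number 16.4 percentage points higher from compound 2 to compound 4 (beyond the scatter), which leaves compound 2 as the only one of the four set apart beyond the scatter. No evidence at hand explains these numbers.

From the compounds shown here alone, it remains open how a group other than an aromatic ring on this nitrogen, such as a short alkyl chain or a saturated cyclic amine, would read, and whether a carboxylic acid on the 4-methylpyridin-2-yl ring would lower the number as it does in compound 2. Going by these compounds, the shared core is the same throughout, so the effect of a hydroxyl or an amine placed on it also stays unknown.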